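The source may hold more compounds than are shown below. What is called first, only, known or untested is meant among the compounds shown, and "the series" means these compounds.

Compound 1 `Cc1cc(NC(=O)c2cc(C(F)(F)F)cc(C(F)(F)F)c2)ccc1NS(C)(=O)=O` was examined in an ADME assay on HEK293 cells (Homo sapiens) for cytotoxicity, read by MTT assay, with a stated time of 48 h (on this read-out higher numbers stand for weaker inhibition and lower numbers for stronger inhibition), where compound 1 gives 163000 nM. Of the two plain numbers shown, compound 1 and compound 2 `CCS(=O)(=O)Nc1ccc(NC(=O)c2ccc(Cl)cc2)cc1C` stand close together, since compound 2 gives 125000 nM and the gap between them lies within the scatter. For compound 3 `CCS(=O)(=O)Nc1ccc(NC(=O)c2ccc(C#N)cc2)cc1C` this assay reports only a limit, > 250000 nM. For the measured compounds named here, the one measured step, an at least 2.0-fold higher number from compound 2 to compound 3 (0.30 log units; that floor lies within the scatter), has a floor that rests on (the limit of > 250000 nM in this assay, at which 1 of the 3 values shown sits), so its true size is not known.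

Compound 4 `CCS(=O)(=O)Nc1ccc(NC(=O)c2cc(C(F)(F)F)cc(C(F)(F)F)c2)cc1C` differs from compound 1 by methyl in place of hydrogen on a saturated chain carbon bound to a sulfonyl sulfur. Going by the values given here, none of the measured steps touches this part of the molecule: the only step measured swaps groups on the aromatic carbon of the benzamide, and compound 1 already carries the bis(trifluoromethyl)benzamide that compound 4 keeps. The measured pairs therefore give no guide to the size or direction of this change, and the expectation in this assay is a step no larger than the scatter.

Compound 4 is accordingly expected to give about 170000 nM, within a range of 85000 nM to 340000 nM. That estimate means a step of a 1.0-fold higher number from compound 1 to compound 4 (0.02 log units; within the scatter), expected to stay within the scatter.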

Compound 4, half-maximal inhibitory concentration: 126000 nM
Beside the measured number, compound 4's estimate is 1.3-fold (0.13 log units) above it; measured number inside the range.
By their numbers in this assay, from the lowest: compounds 2, 4 and 1 (each within the scatter of the next). At a limit, above all of these: compound 3.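

The step at the saturated chain carbon bound to a sulfonyl sulfur now has a measured size in this assay, and it is small: a 1.3-fold lower number from compound 1 to compound 4 (0.11 log units; within the scatter). For the compounds shown here, earlier compounds gave no reading at this place, as the only prior step lay on an aromatic carbon of the benzamide part. Methylsulfonyl and ethylsulfonyl therefore cannot be told apart here on the core of compound 1, although this rests on a single pair, and nothing shown gives a reason for the result.

As far as these compounds go, whether a longer chain such as propyl, a ring such as cyclopropyl, or an amine at this place on the sulfonyl group would give a reading beyond the scatter remains open. From the compounds shown here alone, it is also open whether methyl to ethyl reads the same way when the benzamide carries the chloro of compound 2 or the cyano of compound 3.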